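The source may report more compounds than this note shows. Statements on the series, on what has been measured and on what is new or still open speak of the compounds shown alone.

Measured compounds:
- compound 1, `Nc1cccc(Nc2c(C(=O)NCc3ccc(F)cc3)nc(Br)c3cccnc23)c1`, 8000 nM
- compound 2, `COc1cccc(CNC(=O)c2nc(Br)c3cccnc3c2N[C@H]2CC[C@H](N)CC2)c1`, 7000 nM

Both compounds were tested in a functional assay on MDA-MB-435 cells (Homo sapiens) for cytotoxicity, read by MTT assay, with a stated time of 72 h; a higher number here means a weaker inhibitor, a lower number a stronger inhibitor. Compound 1 gives 8000 nM, which is the higher of the two numbers, but the gap to compound 2 is within the usual scatter of this measurement, so the two readings cannot be told apart. Among the compounds with values here, no step between measured compounds that differ in one place is available to guide an expectation.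

Compound 3, `CNCCCNc1c(C(=O)NCc2ccc(F)cc2)nc(Br)c2cccnc12`, has not yet been tested in this assay. It differs from compound 1 in one place: 3-(methylamino)propyl in place of 3-aminophenyl on a nitrogen on an aromatic ring. Nothing in the two measured values shows how a change from a six-membered aromatic ring of carbon only to a five-atom chain without a ring affects the readout, so the expectation rests on the shared core alone.

The step of a 1.3-fold higher number from compound 1 to compound 3 (0.10 log units; within the scatter) is expected to be small, and a change no larger than the scatter would not be surprising. Compound 3 is therefore estimated at 10000 nM, with a likely range from 3000 nM to 30000 nM.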

Compound 3, half-maximal inhibitory concentration: 11000 nM
For compound 3 the middle estimate is 1.1-fold (0.04 log units) below the measured one; low and high end bracket the measured number.
By their numbers in this assay, from the lowest: compounds 2, 1 and 3 (each within the scatter of the next).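

In this assay, putting 3-(methylamino)propyl in place of 3-aminophenyl on a nitrogen on an aromatic ring gives a 1.4-fold higher number from compound 1 to compound 3 (0.14 log units; within the scatter), so the two compounds cannot be told apart. For this one pair, a six-membered aromatic ring of carbon only can therefore give way to a chain with no ring and fewer heavy atoms without a difference that this measurement can resolve. No measured information is available to account for this result.

On these data alone, whether another group on the same nitrogen, such as a carboxylic acid, a primary amine or a longer chain, would give a step beyond the scatter remains open. As far as these compounds go, compound 2 differs from compound 3 in more than one place, so it gives no direct reading of this position, and how far the result carries over to other groups on the shared core also remains open.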